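Phenyl for Chloro at the Cytotoxicity Limit

The source may report more compounds than this note shows. Statements on the series, on what has been measured and on what is new or still open speak of the compounds shown alone.

Compound 1, `CCc1ccc(Cn2cncc2CNc2ccc(-c3nc4ccccc4s3)c(-c3ccccc3)c2)cc1`: in a toxicity assay on NIH3T3 cells (Mus musculus) for cytotoxicity, read by resazurin assay (a higher number here means that more compound is needed for the effect, a lower number that less compound is needed), compound 1 gives > 1000 nM, which is a limit of the assay rather than a number.
Compound 2, `c1ccc(-c2ccc(Cn3cncc3CNc3ccc(-c4nc5ccccc5o4)c(-c4ccccc4)c3)cc2)cc1`: in this assay compound 2 gives > 10000 nM, also a limit and not a number.
Compound 3, `Clc1ccc(Cn2cncc2CNc2ccc(-c3nc4ccccc4s3)c(-c3ccccc3)c2)cc1`: in this assay compound 3 gives > 1000 nM, again only a limit.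

Compound 3 therefore stands at a limit, and the two further values shown are limits as well, so no number ranks these three against one another. Within the data shown here, the single measured step, a step that the two limits leave unreadable from compound 1 to compound 3, runs between two limits and its size cannot be read. Compound 4, `c1ccc(-c2ccc(Cn3cncc3CNc3ccc(-c4nc5ccccc5s4)c(-c4ccccc4)c3)cc2)cc1`, differs from compound 3 in one place: phenyl in place of chloro on an aromatic carbon. Compound 2 carries the same phenyl and sits at the limit of > 10000 nM in this assay, at which 1 of the 3 values shown sits, while compound 3 sits at the limit of > 1000 nM in this assay, at which 2 of the 3 values shown sit. Nothing here points to a step beyond the scatter. Compound 4 is expected to stay at a limit, estimated at 10000 nM with a range from 3000 nM to 30000 nM. The step this estimate means for compound 4, a step that the limit leaves unreadable from compound 3 to compound 4, is expected to be small and toward weaker cytotoxicity if anything.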

Compound 4, half-maximal effective concentration: > 1000 nM
Compound 4 gave a limit, no number; the forecaster's own chance of this, stated with the estimate: 85%; the middle value is on the limit's open side.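

Compound 4 also ends at a limit of the assay, as do compound 1, compound 2 and compound 3, so its steps from these three cannot be read. The compounds shown leave open what concentration of any of them would produce the effect in this assay.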